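Acylating the Amine of a Long-Chain Threonine Amide

This account rests on a few compounds, and the source may have more. Where it says the series, first, only, none or still open, it means among the compounds named here.

Measured so far in a functional assay on A-431 cells (Homo sapiens) for cytotoxicity, read by MTT assay, with a stated time of 48 h; a lower number here means a stronger inhibitor, a higher number a weaker inhibitor:
compound 1, `CCCCCCCCCCCCCCNC(=O)[C@@H](N)[C@@H](C)O`: 14600 nM
compound 2, `CCCCCCCCCCCCCCCCCCNC(=O)[C@@H](N)[C@@H](C)O`: 21300 nM
compound 3, `CCCCCCCCNC(=O)[C@@H](NC(=O)c1nccc2ccccc12)[C@@H](C)O`: 26900 nM

Compound 1 gives the lowest of the three numbers, but the others stand close to it. Going by the values given here, the single one-place step measured, a 1.5-fold higher number from compound 1 to compound 2 (0.16 log units; within the scatter), lengthens the saturated chain and stays within the scatter. Compound 3 differs from compound 1 in two places at once, an acyl group on the amine nitrogen and a different chain, and its value also lies within the scatter of compound 1. Among the compounds with values here, nothing measured so far separates these compounds with confidence.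

Compound 4, `C/C=C/C=C/C(=O)N[C@H](C(=O)NCCCCCCCCCCCCCC)[C@@H](C)O`, has not been measured. It differs from compound 1 in one place: (penta-1,3-dien-1-yl)carbonyl in place of hydrogen on an amine nitrogen. Within the data shown here, no measured step changes this nitrogen alone. Compound 3 carries a different acyl group on the same nitrogen, yet its second difference means its value gives only an indirect hint. The step of a 1.5-fold higher number from compound 1 to compound 2 (0.16 log units; within the scatter) lies within the scatter. The gap between the values of compound 1 and compound 3 lies within the scatter as well. On that basis compound 4 is expected to stay near compound 1, and the step of a 1.2-fold higher number from compound 1 to compound 4 (0.07 log units; within the scatter) is expected to be small. Compound 4 is therefore estimated at 17000 nM, within a range of 6000 nM to 50000 nM.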

Compound 4, half-maximal inhibitory concentration: > 200000 nM
Compound 4 ended at the assay's limit; the forecaster's own chance of this, stated with the estimate: 10%; middle value at least 11-fold (1.07 log units) away from the limit.
By their numbers in this assay, from the lowest: compounds 1, 2 and 3 (each within the scatter of the next). At a limit, above all of these: compound 4.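

The amine nitrogen of compound 1 proves to be a place where a change counts: in this assay, (penta-1,3-dien-1-yl)carbonyl in place of hydrogen gives an at least 13-fold higher number from compound 1 to compound 4 (1.13 log units; beyond the scatter), the only step shown that lies beyond the scatter. Going by these compounds alone, the earlier compounds gave no sign of this, as the one step they offered, a 1.5-fold higher number from compound 1 to compound 2 (0.16 log units; within the scatter), lies within the scatter and concerns the far end of the saturated chain, not this nitrogen. Compound 4 sits at a limit of the assay, so its entry is a limit and not a number: the limit of > 200000 nM in this assay, at which 1 of the 4 values shown sits.

As far as these compounds go, what stays open is whether this large step belongs to the (penta-1,3-dien-1-yl)carbonyl group in particular or to any acyl group on this nitrogen, a question that an acetyl or a saturated hexanoyl group on the core of compound 1 would address. Compound 3, at 26900 nM, does not settle it: it carries a different acyl group on the same nitrogen, but it also has a different chain, so it differs from compound 1 and from compound 4 in two places at once.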